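Chloro at a New Place on the Core of Compound 1

The source may report more compounds than this note shows. Statements on the series, on what has been measured and on what is new or still open speak of the compounds shown alone.

Compound 1 `CC(C)(C)OC(=O)/C=C1/C(=O)Nc2ccccc21` gives, in a functional assay on HCT-116 cells (Homo sapiens) for inhibition, read by CCK-8 assay, with a stated time of 72 h, tested at 20 uM (on this read-out lower numbers stand for less inhibition of growth and higher numbers for more inhibition of growth at the one concentration tested), 89.5%. Going by the values given here, only one other number stands beside it: compound 2 `CC(C)(C)OC(=O)/C=C1/C(=O)Nc2ccc(Cl)cc21`, which carries a chloro in place of hydrogen on an aromatic carbon, gives 89.7% in this assay, and the step of a number 0.2 percentage points higher from compound 1 to compound 2 (within the scatter) lies within the scatter, so the two compounds cannot be told apart on this read-out.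

Compound 3 `CC(C)(C)OC(=O)/C=C1/C(=O)Nc2c(Cl)cccc21` differs from compound 1 by chloro in place of hydrogen on an aromatic carbon. Among the compounds with values here, the one measured step that bears on this change is the one from compound 1 to compound 2, also a chloro in place of hydrogen on an aromatic carbon of the same ring, and it was a number 0.2 percentage points higher from compound 1 to compound 2 (within the scatter). No other step is shown, and nothing in the two numbers points to a direction. On that basis, the expected step in this assay is none beyond the scatter. Compound 3 is therefore expected to give about 89.5% in this assay, within a range from 80% to 95%. That amounts to an expected step of no change at the digits printed from compound 1 to compound 3 (within the scatter).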

Compound 3, percent growth inhibition at one concentration: 89.5%
Beside the measured number, compound 3's estimate shows no gap at the digits printed, and the stated range covers the measured number.
By their numbers in this assay, from the lowest: compounds 1, 3 and 2 (each within the scatter of the next).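

In this assay, chloro in place of hydrogen on this aromatic carbon, ortho to a fused ring and meta to a fused ring, gives no change at the digits printed from compound 1 to compound 3 (within the scatter) at the one concentration tested, so this position shows no measurable response to the change. The earlier pair had shown this for a single placement of chloro, whereas the shared core now has two chloro placements on the same ring, with compound 2 at 89.7% and compound 3 at 89.5% in this comparison, and these two numbers do not separate the placements. Nothing measured here accounts for the absence of a response at this position, and no cause can be given for it.

The compounds shown leave open whether any other group on this aromatic carbon, such as an amine, a carboxylic acid or a longer chain, would move the number beyond the scatter. They also leave open whether compounds 1, 2 and 3 would differ at other concentrations, which a reading at one concentration cannot show.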